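A few compounds are considered here, and "the series" means these few. Any claim that something is new, unique, unknown or untested is made for them only; others in the source may bear on it.

In an assay on HEK293 cells for agonist activity at Toll-like receptor 2 (Homo sapiens) (a higher number here means that more compound is needed for the effect, a lower number that less compound is needed), compound 1 `CCCCCCCCCCCC(=O)OC[C@H](CSC[C@@H](N)C(=O)NCCCS(=O)(=O)O)OC(=O)CCCCCCCCCCC` gives 5560 nM, the second highest of the three numbers measured here. Compound 2 `CCCCCCCCCCCC(=O)OC[C@H](CSC[C@@H](N)C(=O)NC(C)c1ccccc1)OC(=O)CCCCCCCCCCC` gives 9900 nM, and compound 3 `CCCCCCCCCCCC(=O)OC[C@H](CSC[C@@H](N)C(=O)NC(CC)COC)OC(=O)CCCCCCCCCCC` gives 71.8 nM. All three share the same core and differ only in the group on the amide-type nitrogen, and that group matters greatly: a 77-fold lower number from compound 1 to compound 3 (1.89 log units; beyond the scatter), whereas a 1.8-fold higher number from compound 1 to compound 2 (0.25 log units; within the scatter). Compound 4 `CCCCCCCCCCCC(=O)OC[C@H](CSC[C@@H](N)C(=O)NCCN)OC(=O)CCCCCCCCCCC` carries a new group at that position, differing from compound 1 as follows: amino in place of sulfomethyl on a saturated chain carbon, two bonds along the chain from an amide-type nitrogen. Within the data shown here, no measured step exchanges the 3-sulfopropyl for a group bearing an amino group, so the bearing of the earlier steps is indirect. They show, however, that the number can drop far when the sulfopropyl is replaced, as in compound 3 with 71.8 nM, while compound 2 with 9900 nM shows that it need not. The estimate for compound 4 therefore leans toward a lower number, expected as a 4.6-fold lower number from compound 1 to compound 4 (0.67 log units; beyond the scatter) with wide uncertainty, giving an estimated 1200 nM within the expected range of 150 nM to 8000 nM.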

Compound 4, half-maximal effective concentration: 5240 nM
Estimate against measurement, compound 4: 4.4-fold (0.64 log units) below; the measured number falls inside the stated range.
By their numbers in this assay, from the lowest: compound 3; then compounds 4, 1 and 2 (each within the scatter of the next).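

In this assay, putting 2-aminoethyl in place of 3-sulfopropyl on the amide-type nitrogen leaves the number where it was (a 1.1-fold lower number from compound 1 to compound 4 (0.03 log units; within the scatter)), so a sulfo group at the end of this chain is not needed to keep that number, and an amino group there does not bring it down. The other two steps (a 1.9-fold lower number from compound 2 to compound 4 (0.28 log units; within the scatter) and a 73-fold higher number from compound 3 to compound 4 (1.86 log units; beyond the scatter)) place 2-aminoethyl level with 1-phenylethyl and far from 1-(methoxymethyl)propyl, which makes compound 3 the only one of the four that stands apart. Nothing available here explains why these groups give these numbers.

Still open, as far as these compounds go, is which part of the 1-(methoxymethyl)propyl group matters, and a 2-methoxyethyl or a plain 1-methylpropyl group would help to separate its parts. From the compounds shown here alone, it is also open whether a longer chain ending in an amine, such as 3-aminopropyl, or one ending in a carboxylic acid, would match compound 4.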